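Stilbene-chalcone hybrids: aryl ketone variation and growth inhibition

The source may report more compounds than this note shows. Statements on the series, on what has been measured and on what is new or still open speak of the compounds shown alone.

Measured so far:
compound 1 `COc1ccc(/C=C/c2cc(OC)cc(OC)c2/C=C/C(=O)c2cccc(OC)c2)cc1` — 11.6 ug/mL
compound 2 `COc1ccc(/C=C/c2cc(OC)cc(OC)c2/C=C/C(=O)c2ccc(C)cc2)cc1` — 4.8 ug/mL
compound 3 `COc1ccc(/C=C/c2cc(OC)cc(OC)c2/C=C/C(=O)c2ccc(Br)cc2)cc1` — 12.9 ug/mL

In a functional assay on HepG2 cells (Homo sapiens) for antiproliferative activity, read by MTT assay, with a stated time of 48 h (on this read-out higher numbers stand for weaker inhibition and lower numbers for stronger inhibition), compound 1 stands second highest of the three numbers, with compound 3 nearest (a 1.1-fold higher number from compound 1 to compound 3 (0.05 log units; within the scatter)) and compound 2 furthest (a 2.4-fold lower number from compound 1 to compound 2 (0.38 log units; beyond the scatter)). Compound 4 `COc1ccc(/C=C/c2cc(OC)cc(OC)c2/C=C/C(=O)c2ccc(N)cc2)cc1` is not yet measured. Its change from compound 1 is 4-aminophenyl in place of 3-methoxyphenyl on a carbonyl carbon. Among the compounds with values here, the steps that bear on it are those that also exchange the 3-methoxyphenyl for a phenyl carrying a single substituent, a 2.4-fold lower number from compound 1 to compound 2 (0.38 log units; beyond the scatter) and a 1.1-fold higher number from compound 1 to compound 3 (0.05 log units; within the scatter), and these point in different directions; neither covers an aminophenyl, and compound 2 against compound 3 (a 2.7-fold higher number from compound 2 to compound 3 (0.43 log units; beyond the scatter)) shows the substituent itself matters modestly. For compound 4 a small step is therefore expected, a 1.3-fold lower number from compound 1 to compound 4 (0.11 log units; within the scatter), estimated at 9 ug/mL within 3.5 ug/mL to 23 ug/mL.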

Compound 4, half-maximal inhibitory concentration: 7.5 ug/mL
Compound 4: the middle estimate sits 1.2-fold (0.08 log units) above what was measured, and the stated range covers the measured number.
By their numbers in this assay, from the lowest: compounds 2, 4, 1 and 3 (each within the scatter of the next, the first and the last beyond it).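

In this assay the 4-aminophenyl on the carbonyl carbon carries a hydrogen-bond donor that the 3-methoxyphenyl does not, yet a 1.5-fold lower number from compound 1 to compound 4 (0.19 log units; within the scatter) stays inside the usual scatter. Amino on the aromatic carbon also cannot be separated from bromo, with a 1.7-fold lower number from compound 3 to compound 4 (0.24 log units; within the scatter) as the step, or from methyl, with a 1.6-fold higher number from compound 2 to compound 4 (0.19 log units; within the scatter) as the step, even though the step between those two lies beyond the scatter. No supporting data bear on why this donor leaves the number level.

As far as these compounds go, whether a carboxylic acid or a dimethylamino group on this phenyl would also stay within the scatter remains open. So does the reading for an unsubstituted phenyl at this place.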